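Moving the Methyl Group on the Thiophene Ring

A few compounds are considered here, and "the series" means these few. Any claim that something is new, unique, unknown or untested is made for them only; others in the source may bear on it.

Of the compounds shown here, three built on one shared core have been tested in an assay on Sf9 cells for inhibition of protein deacetylase HDAC6 (Homo sapiens), read by fluorescence, with a stated time of 40 min; on this read-out lower numbers stand for stronger inhibition and higher numbers for weaker inhibition. Compound 1 `Cc1ccc(-c2nc(CNc3ccc(C(=O)NO)cc3)n(-c3ccccc3)n2)cc1` gives 224 nM. Compound 2 `O=C(NO)c1ccc(NCc2nc(-c3cc4ccccc4s3)nn2-c2ccccc2)cc1` gives 324 nM. Compound 3 `Cc1ccc(-c2nc(CNc3ccc(C(=O)NO)cc3)n(-c3ccccc3)n2)s1` gives 30.6 nM, the lowest of the three numbers. Replacing the 4-methylphenyl group with a 1-benzothiophen-2-yl gives a 1.4-fold higher number from compound 1 to compound 2 (0.16 log units; within the scatter), whereas replacing it with a 5-methylthiophen-2-yl gives a 7.3-fold lower number from compound 1 to compound 3 (0.86 log units; beyond the scatter), and going from the benzothiophene to the methylthiophene gives an 11-fold lower number from compound 2 to compound 3 (1.02 log units; beyond the scatter). Compound 4 `Cc1ccsc1-c1nc(CNc2ccc(C(=O)NO)cc2)n(-c2ccccc2)n1` has the same atoms as compound 3, joined differently: 3-methylthiophen-2-yl in place of 5-methylthiophen-2-yl on an aromatic carbon. Among the compounds with values here, neither of the two measured steps that reached compound 3 moves a methyl group within the thiophene ring; they show only that the 5-methylthiophen-2-yl group gave lower numbers than the two larger groups tried. A modest weakening is therefore expected from compound 3, a 2.6-fold higher number from compound 3 to compound 4 (0.42 log units; beyond the scatter), with wide uncertainty. Compound 4 is estimated at 80 nM, somewhere between 25 nM and 300 nM.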

Compound 4, half-maximal inhibitory concentration: 30.7 nM
Compound 4: the middle estimate sits 2.6-fold (0.42 log units) above what was measured; low and high end bracket the measured number.
By their numbers in this assay, from the lowest: compounds 3 and 4 (each within the scatter of the next); then compounds 1 and 2 (each within the scatter of the next).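

In this assay, the methyl group can sit on either of these two thiophene carbons with no difference that can be told from scatter: a 1.0-fold higher number from compound 3 to compound 4 (0.00 log units; within the scatter). The low number seen with compound 3 is therefore not tied to the 5-methylthiophen-2-yl group alone, since the 3-methylthiophen-2-yl group holds the same advantage over the two larger groups, with a 7.3-fold lower number from compound 1 to compound 4 (0.86 log units; beyond the scatter) and an 11-fold lower number from compound 2 to compound 4 (1.02 log units; beyond the scatter). No supporting measurement is available to explain why the two methyl placements read alike.

On these data alone, whether the methyl group contributes at all remains open, and a plain thiophen-2-yl group, carrying no methyl, would address that. Also open, as far as these compounds go, is how a longer chain, such as an ethyl group in place of the methyl, would read at either of these places on the thiophene.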